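From 4-methylphenyl to pyridin-2-yl on compound 2

The compounds below may be only part of what the source reports. "The series", "measured", "known", "first", "only" and "open" are said of these compounds alone.

Measured in an ADME assay on MRC5 cells (Homo sapiens) for cytotoxicity, read by fluorescence and resazurin assay, with a stated time of 3 days; a higher number here means a weaker inhibitor, a lower number a stronger inhibitor:
- compound 1 `Cc1cn(C2CCN(Cc3cncc(Oc4cccc(Cl)c4)c3)CC2)c(=O)[nH]c1=O`: > 64000 nM
- compound 2 `Cc1ccc(Oc2cccc(CN3CCC(n4cc(C)c(=O)[nH]c4=O)CC3)c2)cc1`: > 64000 nM
- compound 3 `Cc1cn(C2CCN(Cc3cc(Oc4cc(Cl)cc(Cl)c4)ccn3)CC2)c(=O)[nH]c1=O`: "not determined" (no result reported)

Compound 2 gives > 64000 nM, which is a limit of the assay and not a number. Compound 1 gives > 64000 nM, which is also a limit. Compound 3 has no reported result, so compound 2 has no exact number to be compared with.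

The next compound to be tested is compound 4 `Cc1cn(C2CCN(Cc3cccc(Oc4ccccn4)c3)CC2)c(=O)[nH]c1=O`. It differs from compound 2 in one place: pyridin-2-yl in place of 4-methylphenyl on an oxygen on an aromatic ring. In words, pyridin-2-yl stands in place of 4-methylphenyl on an oxygen on an aromatic ring.

Among the compounds with values here, no two measured compounds differ in just one place, so no measured step can guide this change. Within the data shown here, the only guide is the limit of > 64000 nM in this assay, at which 2 of the 3 values shown sit. In this assay, the expected size of the change is a number no higher from compound 2 to compound 4 (the limit leaves the size open), meaning no expected shift in either direction beyond the scatter. For compound 4 the estimated value is 64000 nM, with an expected range from 32000 nM to 128000 nM, and the assay may well report only a limit again.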

Compound 4, half-maximal inhibitory concentration: > 64000 nM
Compound 4 was reported as a limit; the forecaster's own chance of this, stated with the estimate: 85%; the middle value sits exactly at the limit.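

In this assay compound 2 gives > 64000 nM, which is a limit. Compound 4 gives > 64000 nM, also a limit, so no step can be read between these two compounds. The compounds shown leave open whether pyridin-2-yl in place of 4-methylphenyl changes the read-out at all.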